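Cytotoxicity at the limit across a proline-amide series

A few compounds are considered here, and "the series" means these few. Any claim that something is new, unique, unknown or untested is made for them only; others in the source may bear on it.

Measured compounds:
compound 1, `C[C@H](NC(=O)[C@]1(Cc2ccccc2)CCN1C(=O)OCc1ccc([N+](=O)[O-])cc1)C(N)=O`: > 100000 nM
compound 2, `C[C@H](NC(=O)[C@]1(Cc2ccccc2)CCN1C(=O)OCc1ccccc1)C(=O)N(C)C`: > 100000 nM

In an ADME assay on HELF cells (Homo sapiens) for cytotoxicity, with a stated time of 3 days (a lower number here means that less compound is tolerated, a higher number that more compound is tolerated), compound 1 gives > 100000 nM, which is a limit of the assay rather than a number. In this assay compound 2 gives > 100000 nM, again a limit and not a measured value. Among the compounds with values here, compound 2 therefore stands at the limit of > 100000 nM in this assay, at which 2 of the 2 values shown sit, and the only other value shown stands there as well; neither value can be ordered against the other.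

Compound 3 is `CC(C)C[C@H](NC(=O)[C@]1(Cc2ccccc2)CCN1C(=O)OCc1ccccc1)C(N)=O`. The change from compound 2 to compound 3 is 1-carbamoyl-3-methylbutyl in place of 1-(dimethylcarbamoyl)ethyl on an amide-type nitrogen.

Within the data shown here, no step between two measured compounds is available, so no measured step size can be carried over. Both measured values sit at the same limit, and the change is confined to the amide-type nitrogen substituent, so the step that the limit leaves unreadable from compound 2 to compound 3 is expected to be none beyond the scatter. Compound 3 is expected to give 150000 nM in this assay, with a range of 50000 nM to 500000 nM, and most likely to be reported again only as a limit.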

Compound 3, half-maximal cytotoxic concentration: 50000 nM
The estimate for compound 3 lay 3.0-fold (0.48 log units) above the measured number, within the range that was stated.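

In this assay, within the data shown here, compound 3 gives 50000 nM, the first value in this set that is a number rather than a limit, which shows that a value can be read in this assay when the substituent on the amide-type nitrogen is changed. The other two values remain limits: the limit of > 100000 nM in this assay, at which 2 of the 3 values shown sit. Swapping 1-(dimethylcarbamoyl)ethyl for 1-carbamoyl-3-methylbutyl at this place amounts to an at least 2.0-fold lower number from compound 2 to compound 3 (0.30 log units; that floor lies within the scatter), so only a floor on the step is known and its true size cannot be read.

The entering group differs from the leaving one both in its carbon chain and in its terminal amide, which has lost the two methyl groups on its nitrogen, and this single step does not tell which of the two differences goes with the lower number. Also open, on these data alone, is how this assay would read with a carboxylic acid in place of that terminal amide, or with a chain longer than the one in 1-carbamoyl-3-methylbutyl, and whether any such group would give a number instead of a limit.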